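A few compounds are considered here, and "the series" means these few. Any claim that something is new, unique, unknown or untested is made for them only; others in the source may bear on it.

Measured so far in a functional assay on MDA-MB-231 cells (Homo sapiens) for cytotoxicity, read by MTT assay; on this read-out lower numbers stand for stronger inhibition and higher numbers for weaker inhibition:

compound 1 `COc1ccc(/C=C2\CCC/C(=C\c3ccccc3[N+](=O)[O-])C2=O)cc1` gives 45.1 ug/mL
compound 2 `COc1cccc(/C=C2\CCC/C(=C\c3ccccc3[N+](=O)[O-])C2=O)c1` gives 14.3 ug/mL
compound 3 `CCOc1c(Br)cc(/C=C2\CCC/C(=C\c3cccc([N+](=O)[O-])c3)C2=O)cc1OC` gives 19.3 ug/mL

Compound 3 stands second highest of the three numbers. Its nearest neighbour is compound 2, whose number lies within the scatter of compound 3, so the two cannot be told apart; compound 1 gives a higher number than compound 3, and that gap lies beyond the scatter. Among the compounds with values here, the only measured step, a 3.2-fold lower number from compound 1 to compound 2 (0.50 log units; beyond the scatter), came from moving a methoxy group on one aromatic ring, a change of a quite different kind from the one that leads to compound 4.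

Compound 4 `CCCCOc1c(Br)cc(/C=C2\CCC/C(=C\c3cccc([N+](=O)[O-])c3)C2=O)cc1OC` differs from compound 3 by ethyl in place of hydrogen on a saturated chain carbon, two bonds along the chain from an oxygen on an aromatic ring, that is, the ethoxy on the aromatic ring becomes a butoxy. Within the data shown here, no measured pair here shows what lengthening this chain does, so nothing in the data argues for a step in either direction. The expectation is therefore a step of a 1.0-fold lower number from compound 3 to compound 4 (0.01 log units; within the scatter), which is to say none beyond the scatter. Compound 4 is expected to give about 19 ug/mL in this assay, with a range from 8 ug/mL to 45 ug/mL.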

Compound 4, half-maximal inhibitory concentration: 5.53 ug/mL
Compound 4: the middle estimate sits 3.4-fold (0.54 log units) above what was measured, outside the stated range (below it).
By their numbers in this assay, from the lowest: compound 4; then compounds 2 and 3 (each within the scatter of the next); then compound 1.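

Replacing the ethoxy on the aromatic ring with a butoxy brings a 3.5-fold lower number from compound 3 to compound 4 (0.54 log units; beyond the scatter) in this assay. The earlier compounds shown here gave no view of this position, and this pair shows that the length of the chain on this oxygen matters in this assay: adding an ethyl in place of a hydrogen, with the rest of the molecule unchanged, moves the number beyond the scatter. Nothing available here explains why the butoxy compound gives the lower number.

Going by these compounds, with only ethoxy and butoxy to compare, it remains open whether a longer chain such as hexyloxy would lower the number further or reverse the trend. On these data alone, it is also open whether a branched chain, or a chain ending in an amine or a carboxylic acid, would give a similar step.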